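A Halogen Swap on Compound 2

The compounds below may be only part of what the source reports. "The series", "measured", "known", "first", "only" and "open" are said of these compounds alone.

Within the data shown here, in a functional assay on HL-60 cells (Homo sapiens) for antiproliferative activity, with a stated time of 72 h (a higher number here means a weaker inhibitor, a lower number a stronger inhibitor), compound 2 `OC[C@H]1O[C@@H](n2cnc3c(NCc4ccc(F)c(F)c4F)ncnc32)[C@H](O)[C@@H]1O` gives 13000 nM and compound 1 `COc1cc(CNc2ncnc3c2ncn3[C@@H]2O[C@H](CO)[C@@H](O)[C@H]2O)cc(OC)c1` gives 20200 nM, so compound 2 stands within the scatter of the only other measured compound. Compound 3 `OC[C@H]1O[C@@H](n2cnc3c(NCc4ccc(F)cc4Cl)ncnc32)[C@H](O)[C@@H]1O` differs from compound 2 in one place: 2-chloro-4-fluorophenyl in place of 2,3,4-trifluorophenyl on a saturated chain carbon bound to a nitrogen on an aromatic ring. Among the measured compounds shown here, the sole measured step, a 1.6-fold lower number from compound 1 to compound 2 (0.19 log units; within the scatter), exchanged 3,5-dimethoxyphenyl for 2,3,4-trifluorophenyl at this same place and stayed within the scatter. No step beyond the scatter is therefore expected in this assay. The estimated step is a 1.1-fold lower number from compound 2 to compound 3 (0.03 log units; within the scatter). For compound 3 the expected value is 12000 nM, with an estimated range of 5000 nM to 28000 nM.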

Compound 3, half-maximal inhibitory concentration: 9000 nM
The estimate for compound 3 lay 1.3-fold (0.12 log units) above the measured number; measured number inside the range.
By their numbers in this assay, from the lowest: compounds 3, 2 and 1 (each within the scatter of the next, the first and the last beyond it).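

In this assay, 2-chloro-4-fluorophenyl in place of 2,3,4-trifluorophenyl gives (a 1.4-fold lower number from compound 2 to compound 3 (0.16 log units; within the scatter)), so this position tolerates that change of halogens without a step that can be told from the scatter. Set against 3,5-dimethoxyphenyl, however, 2-chloro-4-fluorophenyl gives the first step here beyond the scatter, though a modest one (a 2.2-fold lower number from compound 1 to compound 3 (0.35 log units; beyond the scatter)). No measurement at hand offers a reason for either step. Still open, going by these compounds, is how a ring carrying an amine or a carboxylic acid would fare at this place, or a longer chain leading to the ring.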